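Carbonyl Substituent Swap Carried Onto an Isomeric Core

The compounds below may be only part of what the source reports. "The series", "measured", "known", "first", "only" and "open" are said of these compounds alone.

Compound 1 `O=C(/C(=C\c1ccc([N+](=O)[O-])c(O)c1)SCc1ccc(Br)cc1)c1ccc(C(F)(F)F)cc1`: 1000 nM in a functional assay on DU-145 cells (Homo sapiens) for inhibition, read by trypan blue exclusion, with a stated time of 96 h; on this read-out lower numbers stand for stronger inhibition of growth and higher numbers for weaker inhibition of growth
Compound 2 `O=C(/C(=C\c1ccc([N+](=O)[O-])c(O)c1)SCc1ccc(Br)cc1)C1CCNC1`: > 100000 nM in this assay, which is a limit of the assay
Compound 3 `O=C(/C(=C\c1ccc(O)c([N+](=O)[O-])c1)SCc1ccc(Br)cc1)C1CCNC1`: > 100000 nM in this assay, which is a limit of the assay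

Compound 2 and compound 1 differ in one place: 4-(trifluoromethyl)phenyl in place of pyrrolidin-3-yl on a carbonyl carbon. This change gave an at least 100-fold lower number from compound 2 to compound 1 (2.00 log units; beyond the scatter), although the starting point is a limit, noted in the limit of > 100000 nM in this assay, at which 2 of the 3 values shown sit. Compound 2 and compound 3 share their atoms but join them differently; the difference between the two cores is not broken down here.

Compound 4 `O=C(/C(=C\c1ccc(O)c([N+](=O)[O-])c1)SCc1ccc(Br)cc1)c1ccc(C(F)(F)F)cc1` stands to compound 3 as compound 1 stands to compound 2: 4-(trifluoromethyl)phenyl in place of pyrrolidin-3-yl on a carbonyl carbon. The surroundings of the carbonyl carbon are described in the same words for both pairs, so this is the same change made on the other core. From the step between compound 2 and compound 1, the change is expected to give an at least 50-fold lower number from compound 3 to compound 4 (1.69 log units; beyond the scatter), resting on an at least 100-fold lower number from compound 2 to compound 1 (2.00 log units; beyond the scatter). Compound 4 is therefore estimated at 2000 nM, with a likely range from 500 nM to 20000 nM.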

Compound 4, concentration for 50% growth inhibition: 10000 nM
Beside the measured number, compound 4's estimate is 5.0-fold (0.70 log units) below it, and the stated range covers the measured number.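

On the second core, the same change again gave a lower number in this assay, an at least 10-fold lower number from compound 3 to compound 4 (1.00 log units; beyond the scatter), so the direction of the change carries over from one core to the other. The core still counts when 4-(trifluoromethyl)phenyl sits on the carbonyl carbon in both compounds, since 4-hydroxy-3-nitrophenyl in place of 3-hydroxy-4-nitrophenyl gave a 10-fold higher number from compound 1 to compound 4 (1.00 log units; beyond the scatter). The readings for compound 2 and compound 3 are limits of the assay and not numbers, so how much of the change carries over stays unknown: the same change on two cores in this assay, an at least 100-fold lower number (2.00 log units; beyond the scatter) from compound 2 to compound 1 and an at least 10-fold lower number (1.00 log units; beyond the scatter) from compound 3 to compound 4; the limit leaves it open whether they differ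

The compounds shown compare only two groups on the carbonyl carbon, pyrrolidin-3-yl and 4-(trifluoromethyl)phenyl, each on the same two cores. As far as these compounds go, it remains open whether a plain phenyl, an open-chain amine or a carboxylic acid at that place would give the same direction on both cores, and whether any such group would bring the cores closer together.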